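The source may hold more compounds than are shown below. What is called first, only, known or untested is meant among the compounds shown, and "the series" means these compounds.

Three compounds have been measured in a functional assay on HeLa cells (Homo sapiens) for inhibition, read by MTT assay, with a stated time of 72 h; a lower number here means a stronger inhibitor, a higher number a weaker inhibitor:

compound 1, `CN(C(=O)NC(=O)c1ccccc1F)c1nc(C(F)(F)F)c(C(=O)N/N=C/c2cc(C(F)(F)F)cc(C(F)(F)F)c2)s1`: 4.98 ug/mL
compound 2, `CN(C(=O)NC(=O)c1cccc(C(F)(F)F)c1)c1nc(C(F)(F)F)c(C(=O)N/N=C/c2cc(C(F)(F)F)cc(C(F)(F)F)c2)s1`: 5.34 ug/mL
compound 3, `CN(C(=O)NC(=O)c1ccccc1F)c1nc(C(F)(F)F)c(C(=O)N/N=C/c2cccc(C(F)(F)F)c2)s1`: 19.1 ug/mL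

Compound 1 and compound 2 differ by 3-(trifluoromethyl)phenyl in place of 2-fluorophenyl on a carbonyl carbon, and that change made a 1.1-fold higher number from compound 1 to compound 2 (0.03 log units; within the scatter). The core of compound 3 differs from that of compound 1 by hydrogen in place of trifluoromethyl on an aromatic carbon, and compound 3 gives the highest number of the three, beyond the scatter from both others. Compound 4, `CN(C(=O)NC(=O)c1cccc(C(F)(F)F)c1)c1nc(C(F)(F)F)c(C(=O)N/N=C/c2cccc(C(F)(F)F)c2)s1`, has not yet been measured in this assay; it differs from compound 3 by 3-(trifluoromethyl)phenyl in place of 2-fluorophenyl on a carbonyl carbon. The place of the change is described in the same words in both pairs, so this is the same change applied to the core of compound 3. Because the earlier step of a 1.1-fold higher number from compound 1 to compound 2 (0.03 log units; within the scatter) stayed within the scatter, the same change is expected to leave compound 4 near its parent, the estimated step being a 1.0-fold higher number from compound 3 to compound 4 (0.02 log units; within the scatter). Compound 4 is therefore estimated at 20 ug/mL in this assay, with a likely range from 10 ug/mL to 40 ug/mL.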

Compound 4, half-maximal inhibitory concentration: 4.81 ug/mL
Compound 4: middle estimate off by 4.2-fold (0.62 log units), on the high side; measured number below the stated range.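

In this assay, 3-(trifluoromethyl)phenyl in place of 2-fluorophenyl gave a 4.0-fold lower number from compound 3 to compound 4 (0.60 log units; beyond the scatter), so this change did not carry over unchanged from one core to the other: the same change on two cores in this assay, a 1.1-fold higher number (0.03 log units; within the scatter) from compound 1 to compound 2 and a 4.0-fold lower number (0.60 log units; beyond the scatter) from compound 3 to compound 4, 4.3-fold (0.63 log units) apart, beyond the scatter of two such steps.
Hydrogen in place of trifluoromethyl on an aromatic carbon gave a 1.1-fold lower number from compound 2 to compound 4 (0.05 log units; within the scatter), so that change also depended on the rest of the molecule: the same change on two cores in this assay, a 3.8-fold higher number (0.58 log units; beyond the scatter) from compound 1 to compound 3 and a 1.1-fold lower number (0.05 log units; within the scatter) from compound 2 to compound 4, 4.3-fold (0.63 log units) apart, beyond the scatter of two such steps.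
These two pairs of steps show that the two changes interact, but they do not show why, or how either change would behave on a further core.

The compounds shown leave open whether the same interaction appears when a methoxy group or a chlorine atom replaces trifluoromethyl on that aromatic carbon.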